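The compounds below may be only part of what the source reports. "The series", "measured", "known", "first", "only" and "open" are said of these compounds alone.

Measured in a functional assay on SK-MEL-2 cells (Homo sapiens) for cytotoxicity; a higher number here means a weaker inhibitor, a lower number a stronger inhibitor:

- compound 1 `Cc1ccc(S(=O)(=O)N2CC(c3ccc(Br)cc3)NC2=O)cc1`: > 253000 nM
- compound 2 `O=C1NC(c2ccc(Br)cc2)CN1S(=O)(=O)c1ccc2c(c1)CCC2`: 32600 nM
- compound 3 `O=C1NC(c2ccc(Cl)cc2)CN1S(=O)(=O)c1ccc2c(c1)CCC2`: 64300 nM

Compound 1 has no exact number, only a limit of the assay: the limit of > 253000 nM in this assay, at which 1 of the 3 values shown sits. Compound 4 `O=C1NC(c2ccc(Br)cc2)CN1S(=O)(=O)c1ccc(Cl)cc1` keeps the rest of compound 1 and makes one change, chloro in place of methyl on an aromatic carbon, para to a large group, so that 4-methylphenyl becomes 4-chlorophenyl.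

Within the data shown here, no measured pair shows this swap, so the evidence is thin. Among the measured compounds shown here, the only measured step, a 2.0-fold higher number from compound 2 to compound 3 (0.29 log units; within the scatter), also puts chloro on an aromatic carbon, but it replaces bromo at a different place in the molecule, and it stays within the scatter. For the measured compounds named here, it suggests only that one halogen swap need not move this assay much. Compound 2 does show that a different group at the site of the change can still give a measured number, 32600 nM.

The expected change is modest, toward a lower number, and uncertain: an at least 2.1-fold lower number from compound 1 to compound 4 (0.32 log units; beyond the scatter). For compound 4 the estimated value is 120000 nM, with an expected range of 40000 nM to 300000 nM.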

Compound 4, half-maximal inhibitory concentration: 111000 nM
Beside the measured number, compound 4's estimate is 1.1-fold (0.03 log units) above it; measured number inside the range.
By their numbers in this assay, from the lowest: compounds 2, 3 and 4 (each within the scatter of the next, the first and the last beyond it). At a limit, above all of these: compound 1.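

In this assay, changing 4-methylphenyl to 4-chlorophenyl gives an at least 2.2-fold lower number from compound 1 to compound 4 (0.35 log units; beyond the scatter) and so turns a compound without an exact number into one with a measured value. This change, para to a large group, is the only step shown here that is read as beyond the scatter, whereas the earlier halogen swap, at a different place in the molecule, stayed within it. As far as these compounds go, its true size remains unknown, because compound 1 has no exact number, only a limit of the assay: the limit of > 253000 nM in this assay, at which 1 of the 4 values shown sits.

Only methyl and chloro are shown at this position, so it remains open whether an amine, a methoxy group or a carboxylic acid there would give a lower or a higher number in this assay. From the compounds shown here alone, it also remains open whether the swap from methyl to chloro would have a similar effect if chloro replaced the bromo group elsewhere in the molecule, since the change has been read only with bromo present.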